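A few compounds are considered here, and "the series" means these few. Any claim that something is new, unique, unknown or untested is made for them only; others in the source may bear on it.

Measured compounds in an assay on CHO cells for displacement of a labelled ligand from adenosine receptor A1 (Homo sapiens), read by scintillation counting, with a stated time of 90 min, in the presence of a further agent that is not named here; on this read-out higher numbers stand for weaker inhibition and lower numbers for stronger inhibition:

compound 1, `CCCn1c(=O)c2[nH]c(-c3ccc(S(=O)(=O)N4CCN(c5ccc(Cl)cc5)CC4)cc3)nc2n(C)c1=O`, gives > 1000 nM, which is a limit of the assay and not a number.
compound 2, `CCCn1c(=O)[nH]c2nc(-c3ccc(S(=O)(=O)N4CCN(c5ccc(Br)cc5)CC4)cc3)[nH]c2c1=O`, gives > 1000 nM, which is a limit of the assay and not a number.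
compound 3, `CCCn1c(=O)[nH]c2nc(-c3ccc(S(=O)(=O)N4CCN(c5ccccc5)C(C)C4)cc3)[nH]c2c1=O`, gives > 1000 nM, which is a limit of the assay and not a number.

Compound 2 therefore stands at a limit only; its value in this assay cannot be placed in order against the other two, both of which also sit at a limit. Among the compounds with values here, the whole set is described by the limit of > 1000 nM in this assay, at which 3 of the 3 values shown sit: no compound gives a number, and no step between measured compounds can be computed.

The next compound in the series is compound 4, `CCCn1c(=O)[nH]c2nc(-c3ccc(S(=O)(=O)N4CCN(c5ccc(F)cc5)CC4)cc3)[nH]c2c1=O`. It differs from compound 2 in one place: fluoro in place of bromo on an aromatic carbon. The change is small, bromo leaving and fluoro entering on the same aromatic carbon of a six-membered aromatic ring of carbon only.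

Within the data shown here, with every measured value at a limit, there is no step to extrapolate from. The expectation for compound 4 in this assay is a step of size a step that the limit leaves unreadable from compound 2 to compound 4, that is, none beyond the scatter, with the most likely outcome again a limit. Compound 4 is estimated at 3000 nM, with a range from 1000 nM to 10000 nM.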

Compound 4, inhibition constant: > 1000 nM
Compound 4: a limit, no number; the forecaster's own chance of this, stated with the estimate: 75%; the middle value is on the limit's open side.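

In this assay compound 4 gives > 1000 nM, a limit and not a number. No new step can be read between compound 2 and compound 4 for fluoro in place of bromo, and the set stands as follows: the limit of > 1000 nM in this assay, at which 4 of the 4 values shown sit.

The compounds shown leave open how strongly any of them inhibits in this assay, and whether compound 2 and compound 4 differ at all.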